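Swapping isopropyl for chloro in a weakly active set

The source may report more compounds than this note shows. Statements on the series, on what has been measured and on what is new or still open speak of the compounds shown alone.

Compound 1 (`O=C1OCC[C@@H]1NC(=S)SCCOc1ccccc1`) gives 53800 nM
Compound 2 (`CC(C)c1ccc(NCC(=O)N[C@H]2CCOC2=O)cc1`) gives > 64000 nM (a limit)
Compound 3 (`CCCCCCCCCCSC(=S)N[C@H]1CCOC1=O`) gives > 64000 nM (a limit)

All three compounds were run in a functional assay on MGC-803 cells (Homo sapiens) for antiproliferative activity, read by MTT assay, with a stated time of 72 h (a lower number here means a stronger inhibitor, a higher number a weaker inhibitor), and only compound 1 returned an actual number. The result for compound 3 is a limit (> 64000 nM). The result for compound 2 is also a limit, and compound 2 stands at the limit of > 64000 nM in this assay, at which 2 of the 3 values shown sit, in the company of compound 3.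

Compound 4 (`O=C(CNc1ccc(Cl)cc1)N[C@H]1CCOC1=O`) has not yet been measured. It matches compound 2 except for one change (chloro in place of isopropyl on an aromatic carbon), which puts chloro in place of isopropyl on an aromatic carbon, para to a large group. Going by the values given here, no two measured compounds differ in just one place, so the data offer no direct guide to this swap.

The expectation in this assay is therefore no step beyond the scatter, in neither direction. It rests on compound 2 alone, whose limit (> 64000 nM) is the only anchor. The expected change is small (an at least 1.0-fold lower number from compound 2 to compound 4 (0.02 log units; that floor lies within the scatter)). For compound 4 the estimated value is 60000 nM with an expected range from 25000 nM to 130000 nM and a fair chance that the assay reports only a limit.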

Compound 4, half-maximal inhibitory concentration: > 64000 nM
Compound 4 gave a limit, no number; the forecaster's own chance of this, stated with the estimate: 60%; middle value at least 1.0-fold (0.02 log units) from the limit.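

Compound 2 and compound 4 both returned limits rather than numbers in this assay, so no step can be read for chloro in place of isopropyl. Compound 2 stands with most of the set: the limit of > 64000 nM in this assay, at which 3 of the 4 values shown sit. The compounds shown leave open whether this swap changes antiproliferative activity at all.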